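A Chloro Substituent on the Core of Compound 1

The source may hold more compounds than are shown below. What is called first, only, known or untested is meant among the compounds shown, and "the series" means these compounds.

Of the compounds shown here, three with a shared core have been measured in an assay on cells for activation of Cystic fibrosis transmembrane conductance regulator (Homo sapiens), read by fluorescence, with a stated time of 10 min; a higher number here means that more compound is needed for the effect, a lower number that less compound is needed. Compound 1 `O=c1c(-c2cccc([N+](=O)[O-])c2)nc2ccccc2n1Cc1ccccc1` gives 9 nM and stands lowest of the three numbers. Compound 2 `O=c1c(-c2cccc(Br)c2)nc2ccccc2n1Cc1ccccc1` gives 330 nM, and compound 3 `N#Cc1cccc(-c2nc3ccccc3n(Cc3ccccc3)c2=O)c1` gives 1000 nM. Both measured steps away from compound 1 change the nitro group on the pendant ring: a 37-fold higher number from compound 1 to compound 2 (1.56 log units; beyond the scatter) and a 110-fold higher number from compound 1 to compound 3 (2.05 log units; beyond the scatter), while a 3.0-fold higher number from compound 2 to compound 3 (0.48 log units; beyond the scatter).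

Compound 4 `O=c1c(-c2cccc([N+](=O)[O-])c2)nc2c(Cl)cccc2n1Cc1ccccc1` takes a different route. Here the change is chloro in place of hydrogen on an aromatic carbon, on an aromatic carbon of a six-membered aromatic ring of carbon only, part of a fused system of two rings; the nitro group of compound 1 is kept. Among the measured compounds shown here, none of the measured steps touches this part of the core, so they offer no direct guide to the size or direction of the change. The large steps seen on the pendant ring show only that this assay responds strongly to changes elsewhere; they do not say what a chloro on the core will do.

For the measured compounds named here, with no step bearing on it, compound 4 is expected to stay close to compound 1, with a 1.3-fold higher number from compound 1 to compound 4 (0.12 log units; within the scatter) as the estimated step. Compound 4 is therefore estimated at 12 nM, within a range from 3 nM to 50 nM.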

Compound 4, half-maximal effective concentration: 110 nM
For compound 4 the middle estimate is 9.2-fold (0.96 log units) below the measured one; measured number above the stated range.
By their numbers in this assay, from the lowest: compound 1; then compound 4; then compound 2; then compound 3.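

In this assay the chloro in place of hydrogen gives a 12-fold higher number from compound 1 to compound 4 (1.09 log units; beyond the scatter) while the nitro group on the pendant ring stays as it was in compound 1. Among the compounds shown here, this shows that the response does not depend on the pendant ring alone: the part of the core that no earlier step touched also moves the number, and one entering heavy atom on an aromatic carbon of the six-membered ring of carbon only is enough for a large step. No measurement at hand bears on what lies behind this step.

The compounds shown leave open whether the higher number belongs to chloro in particular or would follow any replacement of hydrogen on this carbon, a question that a fluoro, a methyl or a methoxy group there would address. They also leave open whether a chloro on another carbon of this ring would give a step of similar size, and whether this step would hold with bromo or cyano on the pendant ring in place of nitro.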